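Swapping One Saturated Ring for Another on the Shared Core

The source may report more compounds than this note shows. Statements on the series, on what has been measured and on what is new or still open speak of the compounds shown alone.

Measured so far in a functional assay on Venous blood for antagonist activity at C-X-C chemokine receptor type 3 (Homo sapiens), read by flow cytometry, with a stated time of 30 min, in the presence of a further agent that is not named here; on this read-out higher numbers stand for weaker inhibition and lower numbers for stronger inhibition:
compound 1 `C[C@@H]1CN(c2sc(C(F)(F)F)nc2-c2nc3cc(OCCO)ccc3[nH]2)CCN1C(=O)Cn1cnc2cccnc21` gives 99.1 nM;
compound 2 `Cc1nc(C)n(CC(=O)N2CCN(c3sc(C(F)(F)F)nc3-c3nc4ccc(C5CCOCC5)cc4[nH]3)C[C@H]2C)n1` gives 123 nM;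
compound 3 `C[C@@H]1CN(c2sc(C(F)(F)F)nc2-c2nc3ccccc3[nH]2)CCN1C(=O)Cn1cc(Cl)cn1` gives 251 nM.

Compound 2 holds the second highest number of the three. Compound 1 sits nearest to it, within the scatter, so the two cannot be ordered; compound 3 shows the higher number, and that gap lies beyond the scatter.

Compound 4 `Cc1nc(C)n(CC(=O)N2CCN(c3sc(C(F)(F)F)nc3-c3nc4ccc(C5CCN(C)CC5)cc4[nH]3)C[C@H]2C)n1` differs from compound 2 in one place: 1-methylpiperidin-4-yl in place of oxan-4-yl on an aromatic carbon. Among the compounds with values here, no measured pair shows this exchange, so nothing here tells how the entering 1-methylpiperidin-4-yl will register. The step is therefore expected to stay within the scatter, with no direction claimed, as a 1.1-fold lower number from compound 2 to compound 4 (0.05 log units; within the scatter). Compound 4 is estimated at 110 nM, in the range 45 nM to 270 nM.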

Compound 4, half-maximal inhibitory concentration in the C-X-C chemokine receptor type 3 assay: 84.7 nM
Beside the measured number, compound 4's estimate is 1.3-fold (0.11 log units) above it; the measured number falls inside the stated range.
By their numbers in the C-X-C chemokine receptor type 3 assay, from the lowest: compounds 4, 1 and 2 (each within the scatter of the next); then compound 3.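

In the C-X-C chemokine receptor type 3 assay, 1-methylpiperidin-4-yl in place of oxan-4-yl on an aromatic carbon gives a 1.5-fold lower number from compound 2 to compound 4 (0.16 log units; within the scatter), the first step read at this position, so the two saturated rings cannot be told apart here. In a physicochemical assay for solubility, in simulated intestinal fluid (on this read-out lower numbers stand for lower solubility and higher numbers for higher solubility), compound 2 gives > 1000 ug/mL, which is a limit of the assay. In the physicochemical assay compound 4 gives > 1020 ug/mL, also a limit, so the step on this read-out cannot be read.

The compounds shown leave open how a carboxylic acid or an open-chain amine would register on this aromatic carbon. They also leave open whether the same exchange would read alike on the core of compound 3.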